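The compounds below may be only part of what the source reports. "The series", "measured", "known", "first", "only" and "open" are said of these compounds alone.

Of the compounds shown here, two built on a shared core have been tested in a functional assay on the whole organism (strain Wistar) for inhibition, with Rattus norvegicus as the target, read by paw edema, with stated times of 30 min and 60 min, at a dose of 50 mg/kg by the oral route; a lower number here means less inhibition, a higher number more inhibition at the dose given (going by the name of the read-out). Compound 1 `Fc1ccc(C2=NN(c3ccccc3)C(c3cn(-c4ccccc4)nc3-c3ccc(Cl)c(Cl)c3)C2)cc1` gives 55.7% in this assay. Compound 2 `Clc1ccc(C2=NNC(c3cn(-c4ccccc4)nc3-c3ccc(Cl)c(Cl)c3)C2)cc1` gives 45.8% in this assay; this is the lower of the two numbers, yet the gap to compound 1 lies within the usual scatter, so the two readings cannot be told apart. Compound 3 `Fc1ccc(C2=NNC(c3cn(-c4ccccc4)nc3-c3ccc(Cl)c(Cl)c3)C2)cc1` has not yet been measured. It differs from compound 2 in one place: fluoro in place of chloro on an aromatic carbon. The exchanged atom sits on an aromatic carbon of a six-membered aromatic ring of carbon only; the rest of the structure is unchanged. Going by the values given here, no measured pair differs by this change alone, and compound 1, which carries the fluoro, differs from compound 2 elsewhere in the structure as well, so the size of the step is not given by the data. The step expected in this assay is small, a number 2.2 percentage points higher from compound 2 to compound 3 (within the scatter), in no direction that the scatter would let one trust. Compound 3 is therefore estimated at 48% in this assay, with a range from 35% to 62%.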

Compound 3, a percentage reported as inhibition, in the whole organism at one dose (the size of the read-out at that dose, not a potency): 40.5%
Estimate against measurement, compound 3: 7.5 percentage points above, within the range that was stated.
By their numbers in this assay, from the lowest: compounds 3, 2 and 1 (each within the scatter of the next, the first and the last beyond it).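

In this assay, the exchange of 4-chlorophenyl for 4-fluorophenyl gives a number 5.3 percentage points lower from compound 2 to compound 3 (within the scatter) and so, at this place para to a large group, the two halogens cannot be told apart. Compound 3 also isolates the amine nitrogen in a ring: hydrogen in place of phenyl gives a number 15.2 percentage points lower from compound 1 to compound 3 (beyond the scatter) as a modest step, so in this single pair the phenyl goes with more inhibition at the dose given. No measurement shown here accounts for either step.

The compounds shown carry only chloro or fluoro at the para place, so it remains open whether a methoxy group, an amine or a carboxylic acid there would move the reading beyond the scatter. As far as these compounds go, it is also open how a methyl, a benzyl or a longer chain on the ring nitrogen would compare with phenyl and hydrogen, and whether the step seen at this one dose would hold at other doses.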